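The source may hold more compounds than are shown below. What is called first, only, known or untested is meant among the compounds shown, and "the series" means these compounds.

Going by the values given here, in a functional assay on MDA-MB-468 cells (Homo sapiens) for antiproliferative activity, read by MTT assay, with a stated time of 72 h (on this read-out higher numbers stand for weaker inhibition and lower numbers for stronger inhibition), only two compounds sharing one core have been measured. Compound 1 `CCn1ccnc1-c1cc(OC)c(OC)c(OC)c1`, with ethyl on an aromatic nitrogen, reads > 100000 nM, which is a limit of the assay and not a number. Among the compounds with values here, compound 2 `COc1cccc(-n2ccnc2-c2cc(OC)c(OC)c(OC)c2)c1`, with 3-methoxyphenyl in that place, gives 10400 nM, the only actual number so far. Within the data shown here, the one measured step, an at least 9.6-fold lower number from compound 1 to compound 2 (0.98 log units; beyond the scatter), lies beyond the scatter, and it starts from the limit of > 100000 nM in this assay, at which 1 of the 2 values shown sits. Compound 3 `COc1cc(OC)cc(-n2ccnc2-c2cc(OC)c(OC)c(OC)c2)c1` keeps compound 2 intact but for one change on the aryl ring: methoxy in place of hydrogen on an aromatic carbon. Among the measured compounds shown here, that measured step swapped a whole substituent, so it bears only loosely on adding a methoxy, and no measured step shows this change itself. A small further fall in this assay is expected, close to the scatter, starting from compound 2 at 10400 nM. The expected size is a 1.7-fold lower number from compound 2 to compound 3 (0.24 log units; within the scatter). For compound 3 the estimate is 6000 nM, with an expected range from 1500 nM to 30000 nM.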

Compound 3, half-maximal inhibitory concentration: 57500 nM
Estimate against measurement, compound 3: 9.6-fold (0.98 log units) below, outside the stated range (above it).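

In this assay the added methoxy brings a 5.5-fold higher number from compound 2 to compound 3 (0.74 log units; beyond the scatter), so this place on the aryl ring, meta to a large group and meta to a methoxy group, does respond to substitution, and the response is towards weaker inhibition. The earlier step showed only that 3-methoxyphenyl reads lower than ethyl on the aromatic nitrogen; this one shows that a further methoxy on that aryl ring does not carry the gain on. Going by these compounds alone, compound 1 remains the one compound held at a limit and not a number: the limit of > 100000 nM in this assay, at which 1 of the 3 values shown sits.

As far as these compounds go, whether the rise belongs to methoxy itself or to any group at this place stays open, and a hydroxyl, a fluorine or an amine there would tell these apart. Also open, from the compounds shown here alone, is whether a chlorine or a carboxylic acid in place of the methoxy of compound 2 would give a lower number.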